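This account rests on a few compounds, and the source may have more. Where it says the series, first, only, none or still open, it means among the compounds named here.

Measured compounds:
Compound 1, `CCCN1CCN(c2ccc(S(=O)(=O)Oc3cccc(Cl)c3)cc2)C1=O`, in a functional assay on M21 cells (Homo sapiens) for antiproliferative activity, read by sulforhodamine B assay, with a stated time of 48 h (on this read-out higher numbers stand for weaker inhibition and lower numbers for stronger inhibition), gives 8600 nM.
Compound 2, `CCCN1CCN(c2ccc(S(=O)(=O)Oc3cccc([N+](=O)[O-])c3)cc2)C1=O`, in this assay gives 38000 nM.
Compound 3, `CCCN1CCN(c2ccc(S(=O)(=O)Oc3ccc(OC)cc3)cc2)C1=O`, in this assay gives 23000 nM.

Among these three numbers, compound 3 stands second highest. Its nearest neighbour is compound 2, and the difference between them, a 1.7-fold lower number from compound 2 to compound 3 (0.22 log units; within the scatter), is within the scatter, so the two cannot be put in order. The gap to compound 1 is larger, a 2.7-fold higher number from compound 1 to compound 3 (0.43 log units; beyond the scatter), beyond the scatter. The remaining measured step, a 4.4-fold higher number from compound 1 to compound 2 (0.65 log units; beyond the scatter), is likewise beyond the scatter.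

Compound 4, `CCCCN1CCN(c2ccc(S(=O)(=O)Oc3ccc(OC)cc3)cc2)C1=O`, is not yet measured. It differs from compound 3 in one place: methyl in place of hydrogen on a saturated chain carbon, three bonds along the chain from an amide-type nitrogen in a ring. All three measured steps swap the aromatic group carried on the oxygen; none of them touches the chain on the ring nitrogen, so none bears directly on this change. Among the measured compounds shown here, they show only that the numbers in this small set move by modest amounts. With nothing measured about the chain, the plainest expectation is that going from propyl to butyl leaves the number near where compound 3 stands, with a step of a 1.2-fold lower number from compound 3 to compound 4 (0.06 log units; within the scatter) expected to stay within the scatter. Compound 4 is therefore estimated at 20000 nM, with a range from 7000 nM to 55000 nM.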

Compound 4, half-maximal inhibitory concentration: > 100000 nM
Compound 4 was reported as a limit; the forecaster's own chance of this, stated with the estimate: 10%; middle value at least 5.0-fold (0.69 log units) from the limit.
By their numbers in this assay, from the lowest: compound 1; then compounds 3 and 2 (each within the scatter of the next). At a limit, above all of these: compound 4.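

Until now, every step swapped the aromatic group on the oxygen, so nothing showed whether the chain mattered; this result shows that it does. One added methyl on a saturated chain carbon, three bonds along the chain from an amide-type nitrogen in a ring, turns propyl into butyl and gives an at least 4.3-fold higher number from compound 3 to compound 4 (0.63 log units; beyond the scatter) in this assay, a step that can match or exceed the largest one among the aromatic groups, a 4.4-fold higher number from compound 1 to compound 2 (0.65 log units; beyond the scatter). The value of compound 4 is a limit, not a number: the limit of > 100000 nM in this assay, at which 1 of the 4 values shown sits.

As far as these compounds go, the true size of the step therefore stays unknown, and this single pair cannot show whether the weakening grows steadily with chain length or whether the same change would act alike with 3-chlorophenyl on the oxygen in place of 4-methoxyphenyl. Also open, from the compounds shown here alone, is how the number would respond to a shorter chain such as ethyl, a longer chain such as pentyl, or a propyl chain ending in a hydroxyl group or an amine.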